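Dropping a Methyl: Expected Clearance of Compound 4

The compounds below may be only part of what the source reports. "The series", "measured", "known", "first", "only" and "open" are said of these compounds alone.

Compound 1, `Cc1cc(F)c2ncn(-c3ccc(C(=O)NC4CC4)s3)c2c1`: 10 mL/min/kg
Compound 2, `Cc1nc2c(Cl)cc(F)cc2n1-c1ccc(C(=O)NC2CC2)s1`: 5 mL/min/kg
Compound 3, `O=C(NC1CC1)c1ccc(-n2cnc3c(Cl)cc(F)cc32)s1`: 7 mL/min/kg

These values come from an in vitro ADME assay on microsomes from liver (Homo sapiens) for pharmacokinetics, read by LC-MS; a higher number here means faster removal of the compound, a lower number slower removal. Compound 1 gives the highest of the three numbers, yet its gaps to compound 3 and to compound 2 both lie within the scatter, so no order among them is claimed. One change, (hydrogen in place of methyl on an aromatic carbon), separates the second pair, and the step is a 1.4-fold higher number from compound 2 to compound 3 (0.15 log units; within the scatter). The same kind of change leads to compound 4, `O=C(NC1CC1)c1ccc(-n2cnc3c(F)cccc32)s1`: hydrogen in place of methyl on an aromatic carbon. The place is not the same: in compound 2 the methyl sits on a five-membered aromatic ring with 2 nitrogen, between two ring nitrogen atoms; in compound 1 it sits on a six-membered aromatic ring of carbon only, meta to a fluoro group. How the cores of compound 1 and compound 2 differ is not broken down here. Because the step of a 1.4-fold higher number from compound 2 to compound 3 (0.15 log units; within the scatter) was small, a step of a 1.2-fold higher number from compound 1 to compound 4 (0.08 log units; within the scatter) of similar size is expected. Compound 4 is estimated at 12 mL/min/kg, with a likely range from 7 mL/min/kg to 22 mL/min/kg.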

Compound 4, clearance: 10 mL/min/kg
For compound 4 the middle estimate is 1.2-fold (0.08 log units) above the measured one, and the stated range covers the measured number.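

In this assay, hydrogen in place of methyl on an aromatic carbon gives no change at the digits printed from compound 1 to compound 4 (within the scatter). Set beside the earlier example, the change gives steps that do not differ between the two cores: the same change on two cores in this assay, a 1.4-fold higher number (0.15 log units; within the scatter) from compound 2 to compound 3 and no change at the digits printed (within the scatter) from compound 1 to compound 4, 1.4-fold (0.15 log units) apart, within the scatter of two such steps

So in these two examples, removing a methyl, at a different place on each core, gave no step beyond the usual scatter of the measurement; this does not show that the same would hold on other cores, and it does not explain why the steps are small. The compounds shown leave open whether an amine or a longer chain in place of the methyl would give a step beyond the scatter. They also leave open how other assays would respond to this change.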